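The source may hold more compounds than are shown below. What is called first, only, known or untested is meant among the compounds shown, and "the series" means these compounds.

Working notes on the series. In a physicochemical assay for lipophilicity, measured as octanol-water partition (on this read-out higher numbers stand for higher lipophilicity and lower numbers for lower lipophilicity), compound 1 `O=C(O)c1cc(I)c(O)c(I)c1` gives 0.08, compound 3 `COc1c(Cl)cc(Cl)c(Cl)c1C(=O)O` gives -0.064, and compound 2 `Cc1ccc(C(=O)c2ccccc2)c(C(=O)O)c1` gives 0.188; the gaps from compound 2 to compound 1 and to compound 3 both lie within the scatter, so the three numbers cannot be told apart. Going by the values given here, no step between measured compounds that differ in one place is available.

Compound 4 `Nc1ccc(C(=O)c2ccccc2)c(C(=O)O)c1` is the unmeasured member. It differs from compound 2 by amino in place of methyl on an aromatic carbon.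

Among the compounds with values here, on this change the expected step of a number 1.09 log units lower from compound 2 to compound 4 (beyond the scatter) is a clear fall beyond the scatter, since no measured pair shows the change and the expectation rests on the counted difference alone. Compound 4 is estimated at -0.9, within a range from -1.7 to -0.1.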

Compound 4, partition coefficient: -0.048
For compound 4 the middle estimate is 0.85 log units below the measured one, outside the stated range (above it).
By their numbers in this assay, from the lowest: compounds 3, 4, 1 and 2 (each within the scatter of the next).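

Going by these compounds alone, this is the first measured pair for the change: with amino in place of methyl on an aromatic carbon, meta to a carboxy group and para to a group of 8 heavy atoms, this assay gives a number 0.24 log units lower from compound 2 to compound 4 (within the scatter). At this position, the change therefore cannot be told apart from no change on this read-out. No measurement available speaks to the reason.

Going by these compounds, whether the same holds for this change elsewhere on the shared core remains open. Also open, on these data alone, is whether a hydroxy group or a longer chain at this position would stand apart from compound 2 beyond the scatter.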